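This account rests on a few compounds, and the source may have more. Where it says the series, first, only, none or still open, it means among the compounds named here.

Of the compounds shown here, three sharing one core have been measured in an assay on CHO cells for displacement of a labelled ligand from Glucagon receptor (Homo sapiens), read by scintillation counting, with a stated time of 60 min; on this read-out higher numbers stand for weaker inhibition and lower numbers for stronger inhibition. Compound 1 `C[C@H](c1ccc(C(=O)NCCC(=O)O)cc1)N1C(=O)C(c2cccc(C3CC3)c2)=N[C@]12CC[C@@H](C(C)(C)C)CC2` gives 56 nM. Compound 2 `CC(C)(C)CC[C@H](c1ccc(C(=O)NCc2nn[nH]n2)cc1)N1C(=O)C(c2cncc(Cl)c2)=N[C@]12CC[C@@H](C(C)(C)C)CC2` gives 38 nM, and compound 3 `CC[C@H]1CC[C@]2(CC1)N=C(c1cc(Cl)cc(Cl)c1)C(=O)N2[C@H](CCC(C)(C)C)c1ccc(C(=O)NCc2nn[nH]n2)cc1` gives 44 nM. Compound 2 carries the lowest of these three numbers, yet its separation from compound 3 and its separation from compound 1 both lie within the usual scatter of repeated measurements, so the three stand as a group rather than in an order.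

Compound 4 `CC(C)(C)CC[C@H](c1ccc(C(=O)NCc2nn[nH]n2)cc1)N1C(=O)C(c2ccc(C(F)(F)F)cc2)=N[C@]12CC[C@@H](C(C)(C)C)CC2` has not yet been measured. It differs from compound 2 in one place: 4-(trifluoromethyl)phenyl in place of 5-chloropyridin-3-yl on a carbon with a double bond to nitrogen. Among the measured compounds shown here, no step between measured compounds that differ in only one place is available to guide this change. The three measured values sit close together despite several structural differences among them, so the expectation for compound 4 is a step of no size beyond the scatter, in either direction, which is a 1.3-fold higher number from compound 2 to compound 4 (0.12 log units; within the scatter). Compound 4 is therefore estimated at 50 nM, with a range from 15 nM to 160 nM.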

Compound 4, half-maximal inhibitory concentration: 7 nM
Beside the measured number, compound 4's estimate is 7.1-fold (0.85 log units) above it; the whole stated range lies above it.
By their numbers in this assay, from the lowest: compound 4; then compounds 2, 3 and 1 (each within the scatter of the next).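

The carbon with a double bond to nitrogen is a position where one change alone can shift the result: in this assay, 4-(trifluoromethyl)phenyl in place of 5-chloropyridin-3-yl gives a 5.4-fold lower number from compound 2 to compound 4 (0.73 log units; beyond the scatter) and this step lies beyond the scatter. The earlier compounds shown here differed from one another in several places, so they could not show what this position does on its own. Nothing available explains the size of this step.

As far as these compounds go, the change swaps the ring and its substituent together, replacing a ring nitrogen and a chlorine with an all-carbon ring and a trifluoromethyl group, so the share of each remains open. A 4-chlorophenyl group at this place would help to separate the two, as would 5-(trifluoromethyl)pyridin-3-yl.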